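Switching an ester side chain from alkene to indane

The source may report more compounds than this note shows. Statements on the series, on what has been measured and on what is new or still open speak of the compounds shown alone.

Compound 2 `C=C(C)CCOC(=O)C1=C(C)NC(C)=C(C(=O)OC)C1c1cccc([N+](=O)[O-])c1` gives 23 nM in a functional assay on HEK293 cells for antagonist activity at Voltage-dependent L-type calcium channel subunit alpha-1C (Oryctolagus cuniculus), read by FLIPR (on this read-out higher numbers stand for weaker inhibition and lower numbers for stronger inhibition), the lowest of the three numbers, though its gap to compound 1 `C=CCOC(=O)C1=C(C)NC(C)=C(C(=O)OCC)C1c1cccc([N+](=O)[O-])c1`, which gives 25 nM, is within the scatter. Compound 3 `CCOC(=O)C1=C(C)NC(C)=C(C(=O)OC=O)C1c1cccc([N+](=O)[O-])c1` gives 33300 nM. Compound 4 `COC(=O)C1=C(C)NC(C)=C(C(=O)OC2Cc3ccccc3C2)C1c1cccc([N+](=O)[O-])c1` differs from compound 2 in one place: 2,3-dihydro-1H-inden-2-yl in place of 3-methylbut-3-en-1-yl on an oxygen next to a carbonyl group. For the measured compounds named here, the only measured step at this position, a 1300-fold higher number from compound 1 to compound 3 (3.12 log units; beyond the scatter), shows the ester group can matter greatly, but that step is the change to formyl, not a swap between two carbon chains. Compounds 1 and 2 show two different alkenyl esters giving similar numbers, so a modest shift is expected, a 1.7-fold higher number from compound 2 to compound 4 (0.24 log units; within the scatter). Compound 4 is therefore estimated at 40 nM, with a range from 8 nM to 200 nM.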

Compound 4, half-maximal inhibitory concentration: 72 nM
For compound 4 the middle estimate is 1.8-fold (0.26 log units) below the measured one; measured number inside the range.
By their numbers in this assay, from the lowest: compounds 2 and 1 (each within the scatter of the next); then compound 4; then compound 3.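

Putting 2,3-dihydro-1H-inden-2-yl in place of the open 3-methylbut-3-en-1-yl chain, on an oxygen next to a carbonyl group, gives a 3.1-fold higher number from compound 2 to compound 4 (0.50 log units; beyond the scatter) in this assay. This adds a real but modest loss, and with two rings on this oxygen compound 4 still gives 72 nM, so this position accepts more than open alkenyl chains. Nothing measured here explains the change. Still open, on these data alone, is how a cyclopentyl group or a benzyl group would compare on this oxygen. Either could help show whether the non-aromatic ring or the aromatic ring goes with the loss.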